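Replacing the aromatic group of compound 1

The source may hold more compounds than are shown below. What is called first, only, known or untested is meant among the compounds shown, and "the series" means these compounds.

- Compound 1 `COc1cc(OC)c(C(=O)/C=C/c2ccccc2OC)c(OC)c1`: 8200 nM
- Compound 2 `COc1cc(OC)c(C(=O)/C=C/c2ccccc2)c(OC)c1`: > 20000 nM (a limit, not a number)

Going by the values given here, in an ADME assay on cells (Fibroblast, Homo sapiens) for cytotoxicity, with a stated time of 48 h (a lower number here means a stronger inhibitor, a higher number a weaker inhibitor), compound 1 holds the only actual number so far, since the value for compound 2 is a limit of the assay.

Compound 3 `COc1cc(OC)c(C(=O)/C=C/c2ccc(Cl)cc2)c(OC)c1` differs from compound 1 at one place: 4-chlorophenyl in place of 2-methoxyphenyl on a double-bonded chain carbon bound to a double-bonded chain carbon. The methoxy group is lost and a chlorine is gained.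

Among the compounds with values here, one measured step bears on this, an at least 2.4-fold higher number from compound 1 to compound 2 (0.38 log units; beyond the scatter), where hydrogen takes the place of methoxy on an aromatic carbon. That step points towards a higher number in this assay once the methoxy group has gone. Within the data shown here, no step with chlorine has been measured, so this guide is only partial, and a small rise is the most that can reasonably be expected. The estimated change is a 1.5-fold higher number from compound 1 to compound 3 (0.17 log units; within the scatter), which is a small step towards a higher number. Compound 3 is expected at 12000 nM, with an estimated range of 4000 nM to 25000 nM.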

Compound 3, half-maximal inhibitory concentration: > 20000 nM
Compound 3: a limit, no number (the forecaster's own chance of this, stated with the estimate: 35%); at least 1.6-fold (0.22 log units) between middle value and limit.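

In this assay, the change to 4-chlorophenyl gives an at least 2.4-fold higher number from compound 1 to compound 3 (0.38 log units; beyond the scatter), so a second, different replacement of 2-methoxyphenyl also fails to keep the measurable value of compound 1. Compound 3 gives only a limit, not a number, and adding chlorine to the ring of compound 2 therefore does not restore a measurable value. The step from compound 2 to compound 3 cannot be read because both compounds end at the same limit: the limit of > 20000 nM in this assay, at which 2 of the 3 values shown sit.

On these data alone, the true values of compound 2 and compound 3 remain unknown, so it is unclear how far apart they lie or how far each lies from compound 1. As far as these compounds go, it is also open whether another group on this ring, such as an amine or the longer ethoxy chain, would give a measurable number like that of compound 1.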